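A few compounds are considered here, and "the series" means these few. Any claim that something is new, unique, unknown or untested is made for them only; others in the source may bear on it.

Measured in an assay on isolated protein for inhibition of annexin A2/S100-A10 (Homo sapiens), with a stated time of 5 min, tested at 50 uM; a higher number here means more inhibition at the concentration tested (going by the name of the read-out), a lower number less inhibition:
Compound 1, `Cc1ccc(C(=O)C2=C(O)C(=O)N(CC(C)O)C2c2ccc(C(F)(F)F)cc2)cc1`, gives 102%.
Compound 2, `Cc1ccc(C(=O)C2=C(O)C(=O)N(CC(C)O)C2c2cccc(C(F)(F)F)c2)cc1`, gives 110%.
Compound 3, `Cc1ccc(C(=O)C2=C(O)C(=O)N(CC(C)O)C2c2ccc(C(F)(F)F)cc2C(F)(F)F)cc1`, gives 102%.

All three numbers lie within the scatter of one another, so the data show no ordering among compounds 1, 2 and 3 in this assay. Compound 2 differs from compound 1 by 3-(trifluoromethyl)phenyl in place of 4-(trifluoromethyl)phenyl on a saturated ring carbon, a step of a number 8 percentage points higher from compound 1 to compound 2 (within the scatter). Compound 3 differs from compound 1 by trifluoromethyl in place of hydrogen on an aromatic carbon, a step of no change at the digits printed from compound 1 to compound 3 (within the scatter).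

Compound 4, `Cc1ccc(C(=O)C2=C(O)C(=O)N(CC(C)O)C2c2cc(C(F)(F)F)cc(C(F)(F)F)c2)cc1`, is not yet measured. It differs from compound 2 by trifluoromethyl in place of hydrogen on an aromatic carbon. This is the same kind of change as from compound 1 to compound 3, though the surroundings differ: in compound 3 the entering group sits ortho to a large group, in compound 4 meta to a large group. Because no change at the digits printed from compound 1 to compound 3 (within the scatter) showed no movement, compound 4 is expected to give 106%, a step of a number 4 percentage points lower from compound 2 to compound 4 (within the scatter), estimated to fall between 92% and 118%.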

Compound 4, a percentage reported as inhibition, at one concentration (the size of the read-out at that concentration, not a potency) in the annexin A2/S100-A10 assay: 109%
Beside the measured number, compound 4's estimate is 3 percentage points below it; measured number inside the range.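

In the annexin A2/S100-A10 assay, the step for trifluoromethyl in place of hydrogen on an aromatic carbon is a number 1 percentage points lower from compound 2 to compound 4 (within the scatter), and in a physicochemical assay for solubility, in phosphate buffer, with a stated time of 27 h, at pH 7.4 (on this read-out lower numbers stand for lower solubility and higher numbers for higher solubility), compound 2 gives 4100000 nM and compound 4 gives 2300000 nM, so the same change gives a 1.8-fold lower number from compound 2 to compound 4 (0.25 log units; within the scatter). Set beside the earlier case, the change reads the same on the two cores: the same change on two cores in the annexin A2/S100-A10 assay, no change at the digits printed (within the scatter) from compound 1 to compound 3 and a number 1 percentage points lower (within the scatter) from compound 2 to compound 4, 1 percentage points apart, within the scatter of two such steps. This shows that the change carries across these two cores without a readable difference at the single concentration tested, but it does not show that potency is unaffected or that another core would behave alike.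

The compounds shown leave open whether an amine or a nitrile in place of the entering trifluoromethyl would read the same. They also leave open what a longer chain in place of the hydroxyl-bearing chain would do.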